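Working notes: benzyl to 2-fluorophenyl, compound 1 to compound 4

The source may hold more compounds than are shown below. What is called first, only, known or untested is meant among the compounds shown, and "the series" means these compounds.

Values so far in a toxicity assay on cells (Macrophage, Mus musculus, strain BALB/c) for cytotoxicity, read by MTT assay; on this read-out lower numbers stand for stronger inhibition and higher numbers for weaker inhibition:
- compound 1 `C=CCOc1cc(OC)c(C(=O)/C=C/Cc2ccccc2)c(OCC=C)c1`: 14800 nM
- compound 2 `COCc1cc(O)c(C(=O)/C=C/c2cc(OC)c(OC)c(OC)c2)c(OC)c1`: 133000 nM
- compound 3 `COc1cc(O)cc(O)c1C(=O)/C=C/c1ccc(F)cc1`: 28800 nM

Compound 1 (14800 nM) lies within the usual scatter of compound 3 (28800 nM). Compound 2 (133000 nM) stands at a higher number than compound 1, beyond the scatter.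

Compound 4 `C=CCOc1cc(OC)c(C(=O)/C=C/c2ccccc2F)c(OCC=C)c1` keeps the core of compound 1 and carries 2-fluorophenyl in place of benzyl on a double-bonded chain carbon bound to a double-bonded chain carbon.

Among the measured compounds shown here, no measured pair isolates this change, so the expectation rests on three compounds with differing structures. Compound 3 (28800 nM) also carries a fluorine-bearing phenyl ring and gives no ground for expecting a large step from compound 1. Compound 2 (133000 nM) shows that numbers in this small set can spread widely, so the range stays broad. The estimated 1.2-fold higher number from compound 1 to compound 4 (0.09 log units; within the scatter) is expected to stay within the scatter, with a slight lean toward a higher number. For compound 4 the expected value is 18000 nM with an estimated range from 6000 nM to 55000 nM in this assay.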

Compound 4, half-maximal inhibitory concentration: 13300 nM
Estimate against measurement, compound 4: 1.4-fold (0.13 log units) above; measured number inside the range.
By their numbers in this assay, from the lowest: compounds 4, 1 and 3 (each within the scatter of the next, the first and the last beyond it); then compound 2.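

Among the compounds shown here, exchanging benzyl for 2-fluorophenyl on a double-bonded chain carbon bound to a double-bonded chain carbon gives a 1.1-fold lower number from compound 1 to compound 4 (0.05 log units; within the scatter) in this assay, the first single-place comparison, and the step stays within the usual scatter. Read one bond further out, as 3-phenylprop-1-en-1-yl to 2-(2-fluorophenyl)ethenyl, the same step joins the altered chain and the fluorine, so this one pair cannot assign any share of the step to either. Nothing on hand offers an explanation for this outcome.

The compounds shown leave open whether 2-phenylethenyl without fluorine would read like compound 1 and compound 4. They also leave open whether an amine, a carboxylic acid or a longer chain at this position would give a step beyond the scatter.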